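The source may report more compounds than this note shows. Statements on the series, on what has been measured and on what is new or still open speak of the compounds shown alone.

Measured compounds in an ADME assay on J774 cells (Mus musculus) for cytotoxicity; a lower number here means that less compound is needed, a higher number that more compound is needed for the effect:
Compound 1 `Cc1[nH]c2ccccc2c(=O)c1Cc1ccccc1` gives only a limit of the assay, > 40100 nM.
Compound 2 `Cc1[nH]c2ccccc2c(=O)c1Br` gives only a limit of the assay, > 42000 nM.
Compound 3 `COc1ccc2[nH]c(C)c(Br)c(=O)c2c1` gives only a limit of the assay, > 37300 nM.

All three results are limits rather than numbers, so none of these compounds can be ranked against another in this assay. The change from compound 2 to compound 3 is methoxy in place of hydrogen on an aromatic carbon. Its step, a step that the two limits leave unreadable from compound 2 to compound 3, stays unreadable because the limit of > 42000 nM in this assay, at which 1 of the 3 values shown sits, and the limit of > 37300 nM in this assay, at which 1 of the 3 values shown sits, are both limits.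

Compound 4 `COc1ccc2c(=O)c(Cc3ccccc3)c(C)[nH]c2c1` is not yet measured. It arises from compound 1 by methoxy in place of hydrogen on an aromatic carbon, the same change at the same place. How the core of compound 1 differs from the core of compound 2 is not broken down here. Given that the matching step left compound 3 at a limit, the step that the limit leaves unreadable from compound 1 to compound 4 is expected to be small. In this assay compound 4 is therefore expected near 60000 nM, between 30000 nM and 200000 nM, and most likely reported once more only as a limit.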

Compound 4, half-maximal effective concentration: > 35800 nM
Compound 4 gave a limit, no number (the forecaster's own chance of this, stated with the estimate: 85%); the middle value lies beyond the limit too.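

Compound 1 and compound 4 both give only limits in this assay, and the step between them cannot be read. The compounds shown leave open what concentration any of them needs for the effect in this assay.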